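Ester variation on a naphthoquinone core in DU-145 cells

The source may report more compounds than this note shows. Statements on the series, on what has been measured and on what is new or still open speak of the compounds shown alone.

Measured compounds:
Compound 1, `CC(C)=CC[C@@H](OC(=O)CCO)C1=CC(=O)c2c(O)ccc(O)c2C1=O`, gives 55300 nM in a functional assay on DU-145 cells (Homo sapiens) for cytotoxicity, read by MTT assay; on this read-out higher numbers stand for weaker inhibition and lower numbers for stronger inhibition.
Compound 2, `CCCCC(CC(=O)O[C@H](CC=C(C)C)C1=CC(=O)c2c(O)ccc(O)c2C1=O)OC(C)=O`, gives 67700 nM in this assay.
Compound 3, `CC(C)=CC[C@@H](OC(=O)C1CCOC1)C1=CC(=O)c2c(O)ccc(O)c2C1=O`, gives 47500 nM in this assay.

Compound 2 has the highest of the three numbers, yet its steps to compound 1 and compound 3 are both within the scatter, so no ranking can be drawn. Compound 4, `CC(C)=CC[C@@H](OC(=O)C1CCCOC1)C1=CC(=O)c2c(O)ccc(O)c2C1=O`, differs from compound 2 by oxan-3-yl in place of 2-acetoxyhexyl on a carbonyl carbon. The nearest measured step is a 1.4-fold lower number from compound 2 to compound 3 (0.15 log units; within the scatter), where a five-membered ring with one oxygen replaces the same chain; a 1.2-fold lower number from compound 1 to compound 3 (0.07 log units; within the scatter) likewise stays within the scatter. A six-membered ring of the same kind is therefore expected to behave similarly, and compound 4 is estimated at 50000 nM, between 25000 nM and 100000 nM, a step of a 1.4-fold lower number from compound 2 to compound 4 (0.13 log units; within the scatter) that is not expected to exceed the scatter.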

Compound 4, half-maximal inhibitory concentration: 29700 nM
Compound 4: middle estimate off by 1.7-fold (0.23 log units), on the high side, within the range that was stated.
By their numbers in this assay, from the lowest: compounds 4, 3, 1 and 2 (each within the scatter of the next, the first and the last beyond it).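

In this assay, among these compounds, the step of a 2.3-fold lower number from compound 2 to compound 4 (0.36 log units; beyond the scatter) is the first at this position to go beyond the scatter, so swapping 2-acetoxyhexyl for oxan-3-yl on the carbonyl carbon can shift the number modestly. The steps of a 1.6-fold lower number from compound 3 to compound 4 (0.20 log units; within the scatter) and a 1.9-fold lower number from compound 1 to compound 4 (0.27 log units; within the scatter) both stay within the scatter, so oxan-3-yl cannot be told apart from oxolan-3-yl or 2-hydroxyethyl. Among the compounds shown here, nothing available explains the one larger step. Still open, on these data alone, is whether an amine or a carboxylic acid at this position would give a larger step than these neutral groups. The compounds shown also leave open whether the shared core would respond to changes elsewhere.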